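The source may hold more compounds than are shown below. What is called first, only, known or untested is meant among the compounds shown, and "the series" means these compounds.

Two chalcone-like analogues share a core and differ only in the aryl group at one end. Compound 1 `CC1=C(/C=C/C(=O)/C=C/c2ccc(C)cc2)C(C)(C)CCC1` carries a 4-methylphenyl there, and in a functional assay on HeLa cells (Homo sapiens) for cytotoxicity, read by sulforhodamine B assay, with a stated time of 48 h (on this read-out lower numbers stand for stronger inhibition and higher numbers for weaker inhibition), compound 1 gives 20400 nM. Compound 2 `CC1=C(/C=C/C(=O)/C=C/c2ccccc2F)C(C)(C)CCC1` carries a 2-fluorophenyl, and in this assay compound 2 gives 41900 nM. Among the two numbers measured, compound 2 stands highest, with a 2.1-fold higher number from compound 1 to compound 2 (0.31 log units; beyond the scatter) separating it from compound 1.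

Compound 3 `CC1=C(/C=C/C(=O)/C=C/c2cccnc2)C(C)(C)CCC1` takes the next step: pyridin-3-yl in place of 2-fluorophenyl on a double-bonded chain carbon bound to a double-bonded chain carbon. Going by the values given here, only one measured step bears on this, the exchange of one aryl group for another along the same chain carbon, and that step, a 2.1-fold higher number from compound 1 to compound 2 (0.31 log units; beyond the scatter), was modest. The present change also swaps one six-membered aromatic ring for another, so a step of comparable size is expected in this assay, though the direction cannot be read from a single prior step. The number for compound 3 in this assay is therefore estimated at 30000 nM, within a range of 10000 nM to 90000 nM, which amounts to an expected 1.4-fold lower number from compound 2 to compound 3 (0.15 log units; within the scatter).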

Compound 3, half-maximal inhibitory concentration: 17400 nM
Compound 3: the middle estimate sits 1.7-fold (0.24 log units) above what was measured; the range from low to high includes it.
By their numbers in this assay, from the lowest: compounds 3 and 1 (each within the scatter of the next); then compound 2.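

At this chain carbon, pyridin-3-yl, the only ring among the three with a hetero atom and a hydrogen-bond acceptor, brings the number in this assay back down, with a 2.4-fold lower number from compound 2 to compound 3 (0.38 log units; beyond the scatter) as the step, so a change of aryl group here can lower the number as well as raise it, which the earlier step alone could not show. Against 4-methylphenyl, the same pyridin-3-yl gives a 1.2-fold lower number from compound 1 to compound 3 (0.07 log units; within the scatter) as the step, so these two groups cannot be told apart in this read-out, and 2-fluorophenyl alone stands apart from both, by modest steps only. Nothing measured on these compounds offers an explanation for these differences.

As far as these compounds go, what pyridin-4-yl or 4-aminophenyl would give at this chain carbon stays open, so it cannot yet be said whether the place of the ring nitrogen matters or whether other groups would move the number further. Compounds 1 and 2 also differ in both the substituent and where it sits on the ring, and a 4-fluorophenyl would be needed to separate those two changes.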